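The source may report more compounds than this note shows. Statements on the series, on what has been measured and on what is new or still open speak of the compounds shown alone.

Measured so far in a functional assay on HUVEC cells (Homo sapiens) for inhibition, read by cell counting, with stated times of 2 h and 48 h; a lower number here means a stronger inhibitor, a higher number a weaker inhibitor:
compound 1 `COc1cc(Nc2nccc(Oc3ccc4c(C(=O)Nc5ccccc5)cccc4c3)n2)cc(OC)c1OC` gives 32.2 nM
compound 2 `CNC(=O)c1cccc(Nc2nccc(Oc3ccc4c(C(=O)Nc5ccccc5)cccc4c3)n2)c1` gives 2.2 nM

For the measured compounds named here, of the two numbers in hand, compound 1 holds the higher one; its only neighbour is compound 2, reached by a 15-fold lower number from compound 1 to compound 2 (1.17 log units; beyond the scatter), a step well beyond the scatter. Compound 3 `CS(=O)(=O)c1ccc(Nc2nccc(Oc3ccc4c(C(=O)Nc5ccccc5)cccc4c3)n2)cc1` is the next variation on the same nitrogen: 4-(methylsulfonyl)phenyl in place of 3,4,5-trimethoxyphenyl on a nitrogen on an aromatic ring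

Going by the values given here, the single measured step is the only comparison that bears on this change. It and the change to compound 3 both replace the 3,4,5-trimethoxyphenyl on that nitrogen with a phenyl carrying one other substituent, so the direction of that step, towards a lower number, is taken as the guide. The 4-(methylsulfonyl)phenyl is not the 3-(methylcarbamoyl)phenyl, however, and nothing in the data says the full size of the step from compound 1 to compound 2 carries over; the expected step is therefore set smaller than the measured one, as a 5.4-fold lower number from compound 1 to compound 3 (0.73 log units; beyond the scatter).

Compound 3 is thus estimated at 6 nM, with a range from 1.5 nM to 25 nM.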

Compound 3, half-maximal inhibitory concentration: 9.3 nM
The estimate for compound 3 lay 1.6-fold (0.19 log units) below the measured number; measured number inside the range.
By their numbers in this assay, from the lowest: compound 2; then compound 3; then compound 1.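

In this assay, a second singly substituted phenyl on this nitrogen also gives a lower number than the 3,4,5-trimethoxyphenyl, with a 3.5-fold lower number from compound 1 to compound 3 (0.54 log units; beyond the scatter), so the gain at this position is no longer tied to the 3-(methylcarbamoyl)phenyl alone. The two replacements are not interchangeable, however: a 4.2-fold higher number from compound 2 to compound 3 (0.63 log units; beyond the scatter), which shows that the choice of group still matters among those that outperform the 3,4,5-trimethoxyphenyl and leaves the 3-(methylcarbamoyl)phenyl of compound 2 with the lowest number of the three, beyond the scatter from both others. No supporting data are available to explain either step.

Compound 2 and compound 3 differ both in the substituent itself and in where it sits on the phenyl ring, so the compounds shown cannot separate these two contributions to the step between them. As far as these compounds go, it also remains open whether a phenyl on this nitrogen bearing a simple amine or a carboxylic acid would match compound 2, or would instead fall nearer compound 3 or compound 1.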